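Trifluoromethyl in Place of Chloro on the Anilino Ring

A few compounds are considered here, and "the series" means these few. Any claim that something is new, unique, unknown or untested is made for them only; others in the source may bear on it.

Compound 3 `FC(F)(F)c1ccc(CSc2nc(Nc3ccc(Cl)cc3)c3ccccc3n2)cc1` gives 21500 nM in a functional assay on MCF7 cells (Homo sapiens) for cytotoxicity, read by MTT assay, with a stated time of 72 h (on this read-out lower numbers stand for stronger inhibition and higher numbers for weaker inhibition), the lower of the two numbers reported there. Compound 2 `FC(F)(F)c1ccc(CSc2nc(Nc3cccc(Cl)c3)c3ccccc3n2)cc1` gives 25100 nM in the same assay, with a 1.2-fold lower number from compound 2 to compound 3 (0.07 log units; within the scatter). Compound 1 `CCOc1ccccc1Nc1nc(SCc2ccc(C(F)(F)F)cc2)nc2ccccc12` reaches only a limit in this assay, > 50000 nM (the limit of > 50000 nM in this assay, at which 1 of the 3 values shown sits). From compound 1 the steps were an at least 1.9-fold lower number from compound 1 to compound 2 (0.29 log units; that floor lies within the scatter) and an at least 2.3-fold lower number from compound 1 to compound 3 (0.36 log units; beyond the scatter).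

Compound 4 `FC(F)(F)c1ccc(CSc2nc(Nc3ccc(C(F)(F)F)cc3)c3ccccc3n2)cc1` differs from compound 3 by trifluoromethyl in place of chloro on an aromatic carbon. The measured steps bear on this only loosely: exchanging 3-chlorophenyl for 4-chlorophenyl gave nothing beyond the scatter, and exchanging 2-ethoxyphenyl for either chlorophenyl gave at most a modest gain. A step of no size beyond the scatter is therefore expected, a 1.1-fold lower number from compound 3 to compound 4 (0.03 log units; within the scatter). Compound 4 is estimated at 20000 nM in this assay, between 8000 nM and 50000 nM.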

Compound 4, half-maximal inhibitory concentration: 5100 nM
The estimate for compound 4 lay 3.9-fold (0.59 log units) above the measured number; the whole stated range lies above it.
By their numbers in this assay, from the lowest: compound 4; then compounds 3 and 2 (each within the scatter of the next). At a limit, above all of these: compound 1.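

Moving the chloro group on the anilino ring had given nothing beyond the scatter, but changing the group itself, para to a large group, does matter in this assay: the change gives a 4.2-fold lower number from compound 3 to compound 4 (0.62 log units; beyond the scatter). The 4-(trifluoromethyl)phenyl group also gives a 4.9-fold lower number from compound 2 to compound 4 (0.69 log units; beyond the scatter) and an at least 9.8-fold lower number from compound 1 to compound 4 (0.99 log units; beyond the scatter). The last of these steps is only a floor, since compound 1 stands at a limit: the limit of > 50000 nM in this assay, at which 1 of the 4 values shown sits.

From the compounds shown here alone, what a bromo, nitrile, methoxy or carboxylic acid group would give at this place remains open. The cause of the step cannot be read from these values.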